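The source may hold more compounds than are shown below. What is called first, only, known or untested is meant among the compounds shown, and "the series" means these compounds.

Compound 1, `COc1ccc(C2N=C(SCc3ccccc3Cl)NC(C)=C2C(=O)Nc2ccc(Br)cc2)cc1`: 13.3%
Compound 2, `COc1ccc(C2N=C(SCc3cccc(Cl)c3)NC(C)=C2C(=O)Nc2ccc(Br)cc2)cc1`: 32.8%
Compound 3, `CC1=C(C(=O)Nc2ccc([N+](=O)[O-])cc2)C(c2cccc([N+](=O)[O-])c2)N=C(SCc2ccccc2Cl)N1`: 13.3%

These three compounds were tested in a functional assay on the whole organism (artery, strain albino) with Rattus norvegicus as the target, with a stated time of 600 min, at a dose of 10 mg/kg by the oral route; on this read-out lower numbers stand for less inhibition and higher numbers for more inhibition at the one dose given (going by the name of the read-out). Compound 1 and compound 2 share one core and differ in one place: 3-chlorophenyl in place of 2-chlorophenyl on a saturated chain carbon bound to a sulfur. In this assay that change gave a number 19.5 percentage points higher from compound 1 to compound 2 (beyond the scatter), a step that lies beyond the scatter of the method. Compound 3 carries a different core; how its core differs from that of compound 1 is not broken down here. In this assay compound 3 gives 13.3%, which stands level with compound 1 at the digits printed, so nothing can be said of an order between them, while compound 2 sits higher than both.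

The unmeasured compound 4, `CC1=C(C(=O)Nc2ccc([N+](=O)[O-])cc2)C(c2cccc([N+](=O)[O-])c2)N=C(SCc2cccc(Cl)c2)N1`, is built from compound 3 by the same change that turns compound 1 into compound 2: 3-chlorophenyl in place of 2-chlorophenyl on a saturated chain carbon bound to a sulfur. The place of the change is the same in words in both pairs, so this is the same change on a second core. Among the measured compounds shown here, only one earlier instance of it is on hand, so the expectation rests on a single step, and whether a second core answers in the same way is not known from these data. Because compound 1 to compound 2 gave a number 19.5 percentage points higher from compound 1 to compound 2 (beyond the scatter), a step of similar direction but tempered size is expected for compound 4, namely a number 14.7 percentage points higher from compound 3 to compound 4 (beyond the scatter). For compound 4 the estimated value is 28%. The expected range for compound 4 runs from 10% to 48%.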

Compound 4, a percentage reported as inhibition, in the whole organism at one dose (the size of the read-out at that dose, not a potency): 19%
Estimate against measurement, compound 4: 9 percentage points above; the range from low to high includes it.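

In this assay, putting 3-chlorophenyl in place of 2-chlorophenyl on the core of compound 3 gave a number 5.7 percentage points higher from compound 3 to compound 4 (within the scatter), so on this core the effect of the change cannot be told apart from the ordinary spread of repeated measurements. Set beside the earlier step, this result does not show that the second core answers differently from the first, as the gap between the two steps is no larger than the method can resolve: the same change on two cores in this assay, a number 19.5 percentage points higher (beyond the scatter) from compound 1 to compound 2 and a number 5.7 percentage points higher (within the scatter) from compound 3 to compound 4, 13.8 percentage points apart, within the scatter of two such steps Nor does it show that the change carries over reliably: there are only two pairs, one step beyond the scatter and one within it, and they fit a modest rise on both cores as well as they fit no real rise on the second.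

All four compounds carry a chlorophenyl on the saturated chain carbon bound to the sulfur, which leaves open how the read-out would respond to a plain phenyl there or to a longer chain on the sulfur. Also open, going by these compounds, is whether an amine or a carboxylic acid on the aromatic ring of the amide, in place of the bromine or the nitro group, would move the number at all.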